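The source may hold more compounds than are shown below. What is called first, only, known or untested is meant among the compounds shown, and "the series" means these compounds.

Measured compounds in a functional assay on SK-MEL-5 cells (Homo sapiens) for inhibition, read by sulforhodamine B assay, with a stated time of 48 h; on this read-out higher numbers stand for weaker inhibition of growth and lower numbers for stronger inhibition of growth:
compound 1 `Nc1cc(N)c2nc(-c3ccccc3)c(NCc3ccc(Cl)c(Cl)c3)nc2c1` gives 3470 nM
compound 2 `COc1ccc(CNc2nc3cc(N)cc(N)c3nc2-c2ccccc2)cc1OC` gives 10000 nM
compound 3 `COc1cc(CNc2nc3cc(N)cc(N)c3nc2-c2ccccc2)cc(OC)c1OC` gives 724 nM

Among these three, compound 2 stands at the highest number, the weakest inhibitor of growth in this assay: compound 1 lies at a 2.9-fold higher number from compound 1 to compound 2 (0.46 log units; beyond the scatter) away, and compound 3 further still, with a 14-fold lower number from compound 2 to compound 3 (1.14 log units; beyond the scatter) separating them. Compound 4 `COc1ccc(CNc2nc3cc(N)cc(N)c3nc2-c2ccccc2)cc1` is not yet measured. It differs from compound 2 by hydrogen in place of methoxy on an aromatic carbon.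

Among the measured compounds shown here, two measured steps bear on this change. The step from compound 2 to compound 3 shows that adding a methoxy group to the same ring moved the number strongly downward, a 14-fold lower number from compound 2 to compound 3 (1.14 log units; beyond the scatter). The step from compound 1 to compound 2 shows that exchanging the dichlorophenyl for the dimethoxyphenyl moved it upward, a 2.9-fold higher number from compound 1 to compound 2 (0.46 log units; beyond the scatter). Taking away a methoxy group is the reverse of what helped compound 3, so the expectation is a modest rise in this assay, a 1.4-fold higher number from compound 2 to compound 4 (0.15 log units; within the scatter), though the data do not settle whether this methoxy group is the one that matters. Compound 4 is therefore estimated at 14000 nM, within a range from 4000 nM to 40000 nM.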

Compound 4, concentration for 50% growth inhibition: 17800 nM
Compound 4: the middle estimate sits 1.3-fold (0.10 log units) below what was measured, and the stated range covers the measured number.
By their numbers in this assay, from the lowest: compound 3; then compound 1; then compounds 2 and 4 (each within the scatter of the next).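

In this assay, going from the 3,4-dimethoxyphenyl to the 4-methoxyphenyl gives a 1.8-fold higher number from compound 2 to compound 4 (0.25 log units; within the scatter), so the loss of this methoxy group, ortho to a methoxy group, cannot be told apart from the scatter. The added methoxy group on the same ring behaves differently, with a 14-fold lower number from compound 2 to compound 3 (1.14 log units; beyond the scatter), so among these compounds not every methoxy group on this ring counts alike. The 3,4-dichlorophenyl also keeps its lead over the 4-methoxyphenyl, with a 5.1-fold higher number from compound 1 to compound 4 (0.71 log units; beyond the scatter), as it does over the 3,4-dimethoxyphenyl.

Nothing at hand accounts for any of these differences. From the compounds shown here alone, it remains open whether a group other than hydrogen or methoxy at this aromatic carbon, such as a hydroxyl, an amine or a single chlorine, would move the number beyond the scatter.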